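Swapping the para substituent on the aniline of a kinase inhibitor

The compounds below may be only part of what the source reports. "The series", "measured", "known", "first", "only" and "open" are said of these compounds alone.

Compound 2 `CN(C)Cc1ccc(Nc2ncc(C3CC3)c(NCCCNC(=O)C3CCC3)n2)cc1` is the stronger of the two measured compounds in an assay on isolated protein for inhibition of serine/threonine-protein kinase TBK1 (Homo sapiens); on this read-out higher numbers stand for weaker inhibition and lower numbers for stronger inhibition: compound 2 gives 6 nM, while compound 1 `O=C(NCCCNc1nc(Nc2cncnc2)ncc1C1CC1)C1CCC1` gives 3200 nM. For the measured compounds named here, the only measured step is a 530-fold lower number from compound 1 to compound 2 (2.73 log units; beyond the scatter), which came from exchanging a pyrimidinyl for a substituted phenyl on the shared core. Compound 3 `O=C(NCCCNc1nc(Nc2ccc(-n3cncn3)cc2)ncc1C1CC1)C1CCC1` keeps that phenyl but changes what sits on it: 1H-1,2,4-triazol-1-yl in place of (dimethylamino)methyl on an aromatic carbon. Going by the values given here, no measured pair shows this exact exchange, so the step from compound 1 to compound 2 bears on it only indirectly, by showing that the substituted phenyl carries most of the gain over compound 1; whether the (dimethylamino)methyl itself or the phenyl is the decisive part cannot be separated from two compounds. Since compound 2 already holds the lowest number, a move to a higher number is the more likely outcome, and compound 3 is expected to show a 6.7-fold higher number from compound 2 to compound 3 (0.82 log units; beyond the scatter) in this assay. For compound 3 the estimate is 40 nM, with a range from 8 nM to 250 nM.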

Compound 3, half-maximal inhibitory concentration: 3 nM
Estimate against measurement, compound 3: 13-fold (1.12 log units) above, outside the stated range (below it).
By their numbers in this assay, from the lowest: compounds 3 and 2 (each within the scatter of the next); then compound 1.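

In this assay, putting 1H-1,2,4-triazol-1-yl in place of (dimethylamino)methyl gives a 2.0-fold lower number from compound 2 to compound 3 (0.30 log units; within the scatter), so this exchange leaves no difference that can be read on this scale. The position on the six-membered aromatic ring, para to a large group, therefore tolerates two very different groups: (dimethylamino)methyl has no ring and 1 hydrogen-bond acceptor, while 1H-1,2,4-triazol-1-yl is a five-membered aromatic ring with 3 hetero atoms and 3 hydrogen-bond acceptors. This also answers part of what the first two compounds left unresolved, as the (dimethylamino)methyl group is not required for a low number, although no measurement at hand explains why the two groups give such similar results. The compounds shown leave open how a plain phenyl, with only hydrogen at this position, would compare, and so whether any group here contributes to the gain over compound 1. They also leave open whether a morpholine ring, a carboxylic acid or a longer chain ending in an amine would fit this position as well as these two groups do.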